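From Fluoro to Chloro in a Growth Assay

The compounds below may be only part of what the source reports. "The series", "measured", "known", "first", "only" and "open" are said of these compounds alone.

In a functional assay on 786-0 cells (Homo sapiens) (on this read-out higher numbers stand for weaker inhibition of growth and lower numbers for stronger inhibition of growth), compound 1 `Cc1cc(C)c2c(O)cc(-c3ccc(Cl)cc3)nc2n1` gives 21400 nM and compound 2 `Cc1ccnc2nc(-c3ccc(F)cc3)cc(O)c12` gives 33900 nM, so compound 2 stands within the scatter of compound 1. Both numbers lie in the same range. Compound 3 `Cc1ccnc2nc(-c3ccc(Cl)cc3)cc(O)c12` is not yet measured. It has chloro in place of fluoro on an aromatic carbon, para to a large group. Going by the values given here, no measured pair shows this swap on its own, so no change beyond the scatter is expected in this assay. The expected result is a 1.3-fold lower number from compound 2 to compound 3 (0.10 log units; within the scatter) as a small step. Compound 3 is estimated at 27000 nM with a likely range of 13000 nM to 55000 nM on this read-out.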

Compound 3, concentration for 50% growth inhibition: 3980 nM
Beside the measured number, compound 3's estimate is 6.8-fold (0.83 log units) above it, outside the stated range (below it).
By their numbers in this assay, from the lowest: compound 3; then compounds 1 and 2 (each within the scatter of the next).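

In this assay the swap of chloro for fluoro on an aromatic carbon, para to a large group, gives an 8.5-fold lower number from compound 2 to compound 3 (0.93 log units; beyond the scatter) and so shows that this position responds to the choice of halogen. With chloro kept in place, hydrogen in place of methyl on an aromatic carbon gives a 5.4-fold lower number from compound 1 to compound 3 (0.73 log units; beyond the scatter) and so shows that the shared core is sensitive to this change too. No measurement here explains either step. Still open, on these data alone, is how a larger halogen such as bromo, or a methoxy group, would fare at the position para to the large group.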